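Methylsulfonyl Replaced by Hydroxymethyl: an Expected Binding Gain

This account rests on a few compounds, and the source may have more. Where it says the series, first, only, none or still open, it means among the compounds named here.

Compound 1, `Cc1oc(C(=O)O)cc1COc1ccc(-c2ccc(C#N)cc2)cc1`, gives 1500 nM in an assay on cells for displacement of a labelled ligand from prostaglandin E2 receptor EP4 subtype (Homo sapiens), read by scintillation counting; a lower number here means a stronger inhibitor, a higher number a weaker inhibitor.
Compound 2, `Cc1oc(C(=O)O)cc1COc1ccc(-c2ccccc2)cc1`, gives 420 nM in this assay.
Compound 3, `Cc1oc(C(=O)O)cc1COc1ccc(-c2ccc(S(C)(=O)=O)cc2)cc1`, gives > 10000 nM in this assay, which is a limit of the assay and not a number.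

Compound 3 therefore stands at the weak end of the three measured compounds, at the reporting limit, as recorded in the limit of > 10000 nM in this assay, at which 1 of the 3 values shown sits. Compound 4, `Cc1oc(C(=O)O)cc1COc1ccc(-c2ccc(CO)cc2)cc1`, differs from compound 3 by hydroxymethyl in place of methylsulfonyl on an aromatic carbon. Going by the values given here, the steps that bear on this change are an at least 23-fold higher number from compound 2 to compound 3 (1.37 log units; beyond the scatter) and an at least 6.6-fold higher number from compound 1 to compound 3 (0.82 log units; beyond the scatter), both leading into the limit, together with a 3.6-fold lower number from compound 1 to compound 2 (0.55 log units; beyond the scatter). Hydroxymethyl is thus expected to sit between the cyano of compound 1 and the methylsulfonyl of compound 3, giving a step of an at least 4.0-fold lower number from compound 3 to compound 4 (0.60 log units; beyond the scatter) in this assay. For compound 4 the estimated value in this assay is 2500 nM, with a range from 600 nM to 10000 nM.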

Compound 4, inhibition constant: 3000 nM
Beside the measured number, compound 4's estimate is 1.2-fold (0.08 log units) below it, and the stated range covers the measured number.
By their numbers in this assay, from the lowest: compound 2; then compounds 1 and 4 (each within the scatter of the next). At a limit, above all of these: compound 3.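

In this assay, hydroxymethyl gives a measured value at the position where methylsulfonyl gave only a limit, with an at least 3.3-fold lower number from compound 3 to compound 4 (0.52 log units; beyond the scatter), so the loss seen with methylsulfonyl is not shared by every group placed here. Hydroxymethyl still falls short of plain hydrogen, with a 7.1-fold higher number from compound 2 to compound 4 (0.85 log units; beyond the scatter), and it cannot be told apart from cyano, with a 2.0-fold higher number from compound 1 to compound 4 (0.30 log units; within the scatter). The value of compound 3 is a limit, so the step from it gives only a lower bound on the change: the limit of > 10000 nM in this assay, at which 1 of the 4 values shown sits.

The compounds shown leave open whether the hydroxyl hydrogen of hydroxymethyl matters, which methoxymethyl would test. They also leave open whether any group at this position, such as an amine or a carboxylic acid, can match or improve on hydrogen.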